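Series notes: compound 3 to compound 4

The source may hold more compounds than are shown below. What is called first, only, known or untested is meant among the compounds shown, and "the series" means these compounds.

Measured in a physicochemical assay for lipophilicity, read by HPLC; on this read-out lower numbers stand for lower lipophilicity and higher numbers for higher lipophilicity:
- compound 1 `CCCn1cc(C(=O)NCc2ccccc2)c(=O)c2cc(F)c(N3CCC(C(N)=O)CC3)cc21`: 2.4
- compound 2 `CCCCn1cc(C(=O)NCc2ccccc2)c(=O)c2cc(F)c(N(C)C)cc21`: 2.4
- compound 3 `CCCCn1cc(C(=O)NCc2ccccc2)c(=O)c2cc(F)c(N3CCC(C(N)=O)CC3)cc21`: 2.4

Compound 3 stands level with compound 1 and compound 2. Compound 4 `CCCCn1cc(C(=O)NCc2ccccc2)c(=O)c2cc(F)c(N3CCCCC3)cc21` carries hydrogen in place of carbamoyl on a saturated ring carbon. Methyl in place of hydrogen on the chain gave no change at the digits printed from compound 1 to compound 3 (within the scatter), at a different place in the structure. 4-carbamoylpiperidin-1-yl in place of dimethylamino gave no change at the digits printed from compound 2 to compound 3 (within the scatter), but that step brought in ring and carbamoyl together. Going by the values given here, no measured step removes carbamoyl alone, so the size is uncertain. A rise beyond the scatter is expected in this assay, estimated as a number 0.80 log units higher from compound 3 to compound 4 (beyond the scatter). For compound 4 the expected value is 3.2, with an estimated range of 2.6 to 3.9.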

Compound 4, partition coefficient: 2.4
Estimate against measurement, compound 4: 0.80 log units above, outside the stated range (below it).
By their numbers in this assay, from the lowest: compounds 1, 2, 3 and 4 (each within the scatter of the next).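

Hydrogen in place of carbamoyl on the saturated ring carbon gives no change at the digits printed from compound 3 to compound 4 (within the scatter) in this assay, the first step that changes carbamoyl alone. Piperidin-1-yl in place of dimethylamino on the aromatic carbon gives no change at the digits printed from compound 2 to compound 4 (within the scatter), so the ring step now reads apart from the carbamoyl that entered with it earlier. No evidence at hand bears on this result.

Open, from the compounds shown here alone, is whether a carboxylic acid or an amine on that ring carbon would read differently in this assay, or whether the series stays level there too.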